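The source may hold more compounds than are shown below. What is called first, only, known or untested is meant among the compounds shown, and "the series" means these compounds.

Measured compounds:
- compound 1 `COc1cc(C(c2ccc(O)c(OC)c2)[C@H](C)[C@@H](C)CF)ccc1O`: 45000 nM in a functional assay on HL-60 cells (Homo sapiens) for cytotoxicity, read by WST assay, with a stated time of 48 h; a lower number here means a stronger inhibitor, a higher number a weaker inhibitor
- compound 2 `COc1ccc(C(c2ccc(OC)c(OC)c2)[C@H](C)[C@@H](C)CO)cc1OC`: 47000 nM in this assay
- compound 3 `COc1ccc(C(c2ccc(OC)c(OC)c2)[C@H](C)[C@H](C)CO)cc1OC`: a limit of the assay, > 100000 nM in this assay

Compound 1 has the lowest of the two numbers given; compound 2 sits within the scatter of it, so no order between the two can be read. The value of compound 3 is a limit of the assay and not a number (the limit of > 100000 nM in this assay, at which 1 of the 3 values shown sits). Among the measured compounds shown here, the only single-point step within the measured set, an at least 2.1-fold higher number from compound 2 to compound 3 (0.32 log units; beyond the scatter), is an at least modest weakening and rests on a configuration change alone (the fact that compounds 2 and 3 differ only in the configuration as drawn).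

Compound 4 `COc1cc(C(c2ccc(O)c(OC)c2)[C@H](CO)C(C)C)ccc1O` differs from compound 1 in one place: 1-(hydroxymethyl)-2-methylpropyl in place of 2-(fluoromethyl)-1-methylpropyl on a saturated chain carbon bound to two aromatic carbons. For the measured compounds named here, no measured step covers this change itself; the hydroxymethyl-bearing compounds 2 and 3 show that such a side chain is compatible with values near those of compound 1 or with a limit, and the measured step between them speaks only to configuration. A step in this assay of no more than modest size, if any, is therefore expected, with the weakening direction the more likely given the values of compounds 2 and 3. Compound 4 is estimated at 60000 nM, within 25000 nM to 150000 nM. This estimate corresponds to an expected step of a 1.3-fold higher number from compound 1 to compound 4 (0.12 log units; within the scatter).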

Compound 4, half-maximal inhibitory concentration: > 100000 nM
Compound 4 gave a limit, no number; the forecaster's own chance of this, stated with the estimate: 30%; middle value at least 1.6-fold (0.22 log units) from the limit.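

In this assay, placing 1-(hydroxymethyl)-2-methylpropyl in place of 2-(fluoromethyl)-1-methylpropyl on a saturated chain carbon bound to two aromatic carbons gives an at least 2.2-fold higher number from compound 1 to compound 4 (0.34 log units; beyond the scatter), which is a weakening beyond the scatter and the only step shown that rests on a change of group rather than of configuration alone. Compound 4 sits at a limit of the assay, > 100000 nM, so the step sets only a minimum size and the full effect of the change stays unresolved. The limit is now shared, so the upper end of the series is not ordered in this assay: the limit of > 100000 nM in this assay, at which 2 of the 4 values shown sit.

The step swaps the fluoromethyl end for a hydroxymethyl group and also alters the branching and the defined stereocentres, and the compounds shown do not separate these parts of the change. Also open, as far as these compounds go, is whether an amine or a longer chain at this place would bring the value back to a measurable number, and how the opposite configuration of the 1-(hydroxymethyl)-2-methylpropyl group would read.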